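Anilino halogen pattern: from compound 2 to compound 3

The source may report more compounds than this note shows. Statements on the series, on what has been measured and on what is new or still open speak of the compounds shown alone.

Measured in a functional assay on NCI-H522 cells (Homo sapiens) for inhibition, read by sulforhodamine B assay, with a stated time of 48 h; on this read-out higher numbers stand for weaker inhibition of growth and lower numbers for stronger inhibition of growth:
- compound 1 `CN1CCN(CCCOc2cccc3nc(Nc4ccc(Cl)c(C(F)(F)F)c4)ccc23)CC1`: 1830 nM
- compound 2 `CN1CCN(CCCOc2cccc3nc(Nc4ccc(F)c(F)c4)ccc23)CC1`: 1010 nM

On the numbers shown, compound 2 stands at one end of the pair, with compound 1 as its only neighbour, and the step of a 1.8-fold lower number from compound 1 to compound 2 (0.26 log units; within the scatter) does not separate the two in this assay.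

Compound 3 `CN1CCN(CCCOc2cccc3nc(Nc4cc(Cl)cc(Cl)c4)ccc23)CC1` is compound 2 with 3,5-dichlorophenyl in place of 3,4-difluorophenyl on a nitrogen on an aromatic ring. Among the measured compounds shown here, the only measured step that bears on this change is the swap of halogens on the same anilino ring, a 1.8-fold lower number from compound 1 to compound 2 (0.26 log units; within the scatter), which stayed within the scatter. Nothing in the series shows that a rearrangement of two halogens on that ring moves the number in this assay. The step from compound 2 to compound 3 is therefore expected to be a 1.2-fold higher number from compound 2 to compound 3 (0.07 log units; within the scatter), i.e. none beyond the scatter. Compound 3 is estimated at 1200 nM in this assay, with a range of 450 nM to 3200 nM.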

Compound 3, concentration for 50% growth inhibition: 1640 nM
Estimate against measurement, compound 3: 1.4-fold (0.14 log units) below, within the range that was stated.
By their numbers in this assay, from the lowest: compounds 2, 3 and 1 (each within the scatter of the next).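

In this assay, the 3,5-dichlorophenyl group on the anilino nitrogen gives a 1.6-fold higher number from compound 2 to compound 3 (0.21 log units; within the scatter) and a 1.1-fold lower number from compound 1 to compound 3 (0.05 log units; within the scatter), so three different halogen patterns on this ring now stand within the scatter of one another. Among the compounds shown here, the earlier pair offered only one such comparison; the third pattern extends it to a change of halogen and pattern together, and neither step separates the compounds. No measurement available here gives a reason for this flat result, and the series gives no cause for it.

The change from 3,4-difluorophenyl to 3,5-dichlorophenyl alters the halogen and its pattern at once, so the contribution of each remains unresolved. Also open, from the compounds shown here alone, is whether a phenyl ring carrying a methoxy group or a carboxylic acid instead of halogens would move the number beyond the scatter.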